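A few compounds are considered here, and "the series" means these few. Any claim that something is new, unique, unknown or untested is made for them only; others in the source may bear on it.

In an assay on LX2 cells for inhibition of COL1A1 promoter (Homo sapiens), read by a luciferase reporter, with a stated time of 24 h, tested at 50 uM (on this read-out lower numbers stand for a weaker effect and higher numbers for a stronger effect at the one concentration tested), compound 1 `Cc1ccc(-n2cc(C(=O)Nc3cc(F)cc(F)c3)c(=O)c3ccc(N(C)C)nc32)cc1OCCCCCCC[N+]12CCN(CC1)CC2` gives 9.71%.
Compound 2 `CN(C)c1ccc2c(=O)c(C(=O)Nc3cc(F)cc(F)c3)cn(-c3ccc(Cl)c(OCCCCCCC[N+]45CCN(CC4)CC5)c3)c2n1` gives 18.7% in this assay.
Compound 3 `Cc1cc(OCCCCCCC[N+]2(C)CCCCC2)ccc1-n1cc(C(=O)Nc2cc(F)cc(F)c2)c(=O)c2ccc(N(C)C)nc21` is reported as "not active" (no number reported) in this assay, without a number.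

The change from compound 1 to compound 2 is chloro in place of methyl on an aromatic carbon, and it produced a number 9 percentage points higher from compound 1 to compound 2 (within the scatter). Compound 4 `CN(C)c1ccc2c(=O)c(C(=O)Nc3cc(F)cc(F)c3)cn(-c3ccc(OCCCCCCC[N+]4(C)CCCCC4)cc3Cl)c2n1` carries the same kind of change on the core of compound 3, (chloro in place of methyl on an aromatic carbon); here the place is ortho to a large group and meta to a large group, whereas in compound 2 it is ortho to a large group and para to a large group. The difference between the two cores is not broken down here. Compound 3 has no number, so compound 4 starts from a weak footing, and the earlier step lay within the scatter. Compound 4 is therefore expected to give about 8% in this assay, estimated between 0% and 25%.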

Compound 4, a percentage reported as inhibition, at one concentration (the size of the read-out at that concentration, not a potency): "not active" (no number reported)
Compound 4 has no reported number here; no gap can be computed for the estimate.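

No step can be read between compound 3 and compound 4: in this assay compound 3 gives "not active" (no number reported) and compound 4 gives "not active" (no number reported). What chloro in place of methyl does on this core stays open, and nothing measured here offers an explanation for the result.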